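Methoxy to hydroxy on the benzamide of compound 1

The source may hold more compounds than are shown below. What is called first, only, known or untested is meant among the compounds shown, and "the series" means these compounds.

Of the compounds shown here, two have been measured in a functional assay on HCT-116 cells (Homo sapiens) for cytotoxicity, read by resazurin assay, with a stated time of 48 h; on this read-out higher numbers stand for an effect only at larger amounts of compound and lower numbers for an effect already at smaller amounts. Compound 1 `COc1c(Br)cccc1C(=O)Nc1ccc(Sc2nc3ccccc3s2)c(Cl)c1` gives 8500 nM in this assay and so stands at the low end of the two numbers shown. Compound 2 `O=S(=O)(Nc1ccc(-c2nc3cc(NS(=O)(=O)c4ccc(C(F)(F)F)cc4)ccc3o2)cc1)c1ccc(C(F)(F)F)cc1` gives 15000 nM in this assay; its gap to compound 1 lies within the scatter, so the two values cannot be told apart. Within the data shown here, no pair of measured compounds differs in a single place, so no step size is known from the data.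

Compound 3 `O=C(Nc1ccc(Sc2nc3ccccc3s2)c(Cl)c1)c1cccc(Br)c1O` is the next compound for this assay. It differs from compound 1 in one place: hydrogen in place of methyl on an oxygen on an aromatic ring, that is, methoxy to hydroxy. Nothing in the measured pair shows how such a change moves this read-out. For compound 3 the expected step of a 1.4-fold lower number from compound 1 to compound 3 (0.15 log units; within the scatter) is small and not beyond the scatter. The estimate for compound 3 in this assay is 6000 nM, with a range from 2000 nM to 20000 nM.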

Compound 3, half-maximal effective concentration: 12000 nM
For compound 3 the middle estimate is 2.0-fold (0.30 log units) below the measured one, and the stated range covers the measured number.
By their numbers in this assay, from the lowest: compounds 1, 3 and 2 (each within the scatter of the next).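

Methoxy to hydroxy on an oxygen on an aromatic ring now gives the first single-place step of the series in this assay: the result is a 1.4-fold higher number from compound 1 to compound 3 (0.15 log units; within the scatter). Compound 1 and compound 3 cannot be told apart on this read-out, so at this position, methyl and hydrogen on the oxygen show no difference that can be resolved. No available evidence bears on the reason for this result.

Still open, as far as these compounds go, is whether a longer chain on this oxygen, such as ethyl, or an amine in place of the hydroxy group would give a step beyond the scatter. Among these compounds, with only this one step, which lies within the scatter, the size of step that this position can give also remains unknown.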